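Moving On from the Fastest-Cleared Acid

The source may report more compounds than this note shows. Statements on the series, on what has been measured and on what is new or still open speak of the compounds shown alone.

In an ADME assay on the whole organism (strain CD-1) for pharmacokinetics, with Mus musculus as the target, at a dose of 3 mg/kg by the intravenous route (a higher number here means faster removal of the compound, a lower number slower removal), compound 3 `CN(Cc1ccccc1OCCC/C=C/C(=O)O)C(=O)c1ccc(-c2ccco2)cc1` stands highest at 67 mL/min/kg, well above compound 1 `CC(CCCCOc1ccccc1CN(C)C(=O)c1ccc(-c2ccco2)cc1)C(=O)O` at 3 mL/min/kg and compound 2 `CN(Cc1ccccc1OCCC[C@@H]1C[C@H]1C(=O)O)C(=O)c1ccc(-c2ccco2)cc1` at 0.6 mL/min/kg. Compound 4 `C/C(=C\COc1ccccc1CN(C)C(=O)c1ccc(-c2ccco2)cc1)CCC(=O)O` changes the chain of compound 3: 4-carboxy-2-methylbut-1-en-1-yl in place of 4-carboxybut-3-en-1-yl on a saturated chain carbon bound to an oxygen on an aromatic ring. In words, 4-carboxy-2-methylbut-1-en-1-yl replaces 4-carboxybut-3-en-1-yl. Two measured steps altered this same chain, a 22-fold higher number from compound 1 to compound 3 (1.35 log units; beyond the scatter) and a 110-fold higher number from compound 2 to compound 3 (2.05 log units; beyond the scatter). Both are large, so this chain can move this assay strongly. Compound 1 and compound 2 both lack the 4-carboxybut-3-en-1-yl group and sit far lower, though neither carries the new group, so this evidence is indirect. A large drop is therefore expected, with an estimated step of a 6.7-fold lower number from compound 3 to compound 4 (0.83 log units; beyond the scatter). The estimate for compound 4 is 10 mL/min/kg, within a range of 2 mL/min/kg to 40 mL/min/kg.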

Compound 4, clearance: 15 mL/min/kg
Compound 4: the middle estimate sits 1.5-fold (0.18 log units) below what was measured; the measured number falls inside the stated range.
By their numbers in this assay, from the lowest: compound 2; then compound 1; then compound 4; then compound 3.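

Both chains carry the same count of double bonds outside aromatic rings, yet the 4-carboxy-2-methylbut-1-en-1-yl chain gives a 4.5-fold lower number from compound 3 to compound 4 (0.65 log units; beyond the scatter) in this assay and so that count alone does not set the number here. The number still stays above those of the two other chains, with a 25-fold higher number from compound 2 to compound 4 (1.40 log units; beyond the scatter) and a 5.0-fold higher number from compound 1 to compound 4 (0.70 log units; beyond the scatter) as the steps up. Nothing measured here gives a reason for these steps.

Still open, going by these compounds, is whether the fall follows the added methyl or the new place of the double bond. Also open, on these data alone, is how a tetrazole in place of the carboxylic acid would fare.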